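Swapping the pendant aryl ring: expected cytotoxicity of compound 4

This account rests on a few compounds, and the source may have more. Where it says the series, first, only, none or still open, it means among the compounds named here.

Measured so far:
- Compound 1, `COc1ccc(-c2cc(C)c(Nc3ccnc(Nc4ccc(C#N)cc4)n3)c(C)c2)cc1`: 2890 nM
- Compound 2, `Cc1cc(-c2ccc(F)cc2)cc(C)c1Nc1ccnc(Nc2ccc(C#N)cc2)n1`: 4170 nM
- Compound 3, `Cc1cc(-c2ccccc2C(F)(F)F)cc(C)c1Nc1ccnc(Nc2ccc(C#N)cc2)n1`: 4210 nM

These three compounds share a common core and differ only in the aryl ring attached to it. In an ADME assay on MT4 cells (Homo sapiens) for cytotoxicity, read by MTT assay, with a stated time of 4 days (on this read-out higher numbers stand for lower toxicity in this test and lower numbers for higher toxicity in this test), compound 2 gives 4170 nM, a number that lies within the scatter of both companions: the step of a 1.4-fold higher number from compound 1 to compound 2 (0.16 log units; within the scatter) and the step of a 1.0-fold higher number from compound 2 to compound 3 (0.00 log units; within the scatter) are each too small to count as a real difference.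

Compound 4, `Cc1cc(-c2cccc(Cl)c2)cc(C)c1Nc1ccnc(Nc2ccc(C#N)cc2)n1`, has not yet been measured. It differs from compound 2 in one place: 3-chlorophenyl in place of 4-fluorophenyl on an aromatic carbon. For the measured compounds named here, the steps that bear on this change are the exchanges of one aryl ring for another already seen, namely a 1.0-fold higher number from compound 2 to compound 3 (0.00 log units; within the scatter) and a 1.5-fold higher number from compound 1 to compound 3 (0.16 log units; within the scatter), neither of which moved the number beyond the scatter. The change to compound 4 is of the same kind, so no step beyond the scatter is expected in this assay in either direction.

Compound 4 is therefore estimated at 4000 nM, with a range from 2000 nM to 8000 nM, which corresponds to an expected step of a 1.0-fold lower number from compound 2 to compound 4 (0.02 log units; within the scatter).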

Compound 4, half-maximal cytotoxic concentration: 2160 nM
Estimate against measurement, compound 4: 1.9-fold (0.27 log units) above, and the stated range covers the measured number.
By their numbers in this assay, from the lowest: compounds 4, 1, 2 and 3 (each within the scatter of the next).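

With 3-chlorophenyl on this aromatic carbon of the shared core, four different aryl rings have now been tested, and in this assay the new ring still gives no step beyond the scatter: a 1.9-fold lower number from compound 2 to compound 4 (0.29 log units; within the scatter) and a 1.9-fold lower number from compound 3 to compound 4 (0.29 log units; within the scatter) and also a 1.3-fold lower number from compound 1 to compound 4 (0.13 log units; within the scatter) all stay within it. The four rings, carrying methoxy, fluoro, trifluoromethyl or chloro, therefore cannot be told apart in this test. No measurement is available to explain where these values fall. Going by these compounds, it remains open whether an amine, a carboxylic acid or a longer chain in place of the aryl ring would give a step beyond the scatter. Also open, on these data alone, is whether 4-chlorophenyl would read the same as 3-chlorophenyl.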